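This account rests on a few compounds, and the source may have more. Where it says the series, first, only, none or still open, it means among the compounds named here.

Three compounds have been measured so far in a functional assay on MIA PaCa-2 cells (Homo sapiens) for cytotoxicity, read by fluorescence, with a stated time of 48 h; a higher number here means that more compound is needed for the effect, a lower number that less compound is needed

Compound 1 `CC(C)=CCC/C(C)=C/CC/C(C)=C/CSC[C@H](NC(=O)CCCCCN1CCN(C)CC1)C(=O)NC1CCCCCC1` gives 2700 nM
Compound 2 `CC(C)=CCC/C(C)=C/CC/C(C)=C/CSC[C@H](NC(=O)CCCCCN1CCCC1)C(=O)NC1CCCCC1` gives 5600 nM
Compound 3 `CC(C)=CCC/C(C)=C/CC/C(C)=C/CSC[C@H](NC(=O)CCCCCN1CCCC1)C(=O)NC1CCCC1` gives 3200 nM

Compound 1 sits at the low end of these three numbers. Its value and that of compound 3 lie within the usual scatter of each other, while the value of compound 2 stands higher, beyond that scatter.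

The next compound to be tested is compound 4 `CC(C)=CCC/C(C)=C/CC/C(C)=C/CSC[C@H](NC(=O)CCCCCN1CCN(C)CC1)C(=O)NC1CC1` which keeps the core of compound 1 and alters a single group (cyclopropyl in place of cycloheptyl on an amide-type nitrogen). In words, it carries cyclopropyl in place of cycloheptyl on an amide-type nitrogen.

Going by the values given here, only one measured step changes the ring at this nitrogen (a 1.8-fold lower number from compound 2 to compound 3 (0.24 log units; within the scatter)). That step, cyclopentyl in place of cyclohexyl, stays within the scatter. It is only a rough guide, since compound 2 and compound 3 also differ from compound 1 elsewhere, and the ring change in compound 4 is a larger one. The data give no firm direction, so no step beyond the scatter is expected in this assay and the range must stay wide. The expected change is small (a 1.3-fold higher number from compound 1 to compound 4 (0.11 log units; within the scatter)). Compound 4 is therefore estimated at 3500 nM (expected range 1200 nM to 10000 nM).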

Compound 4, half-maximal effective concentration: 10400 nM
Compound 4: middle estimate off by 3.0-fold (0.47 log units), on the low side; measured number above the stated range.
By their numbers in this assay, from the lowest: compounds 1, 3, 2 and 4 (each within the scatter of the next, the first and the last beyond it).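

In this assay, putting cyclopropyl in place of cycloheptyl on the amide-type nitrogen gives a 3.9-fold higher number from compound 1 to compound 4 (0.59 log units; beyond the scatter). Going by these compounds alone, this is the first sign that the group at this position can move the number past the usual scatter, something the only earlier ring change, a 1.8-fold lower number from compound 2 to compound 3 (0.24 log units; within the scatter), could not show. In this single pair, going from a ring of 7 carbons to a ring of 3 means that more compound is needed for the effect, but no measured property is available to explain the shift.

Within the data shown here, with only two ring sizes on the core of compound 1, it remains open whether the number climbs gradually as the ring shrinks or jumps only once the ring becomes very small, and a cyclobutyl group on this nitrogen, or an open chain such as hexyl, would help separate those cases. From the compounds shown here alone, it also remains open whether cyclopropyl would give a similar step on the core of compound 2, where the far end of the amide chain differs.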